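Moving a Methyl Group in a Series at the Limit

A few compounds are considered here, and "the series" means these few. Any claim that something is new, unique, unknown or untested is made for them only; others in the source may bear on it.

In a functional assay on COLO 205 cells (Homo sapiens) for cytotoxicity, read by MTT assay, with a stated time of 48 h (a lower number here means a stronger inhibitor, a higher number a weaker inhibitor), three compounds built on a shared core have been tested. Compound 1 `Fc1cccc(Nc2nc(-c3cccc(F)c3)nc3ccc(F)cc23)c1` gives > 50000 nM as its result, which is a limit and not a number. Compound 2 `Fc1cccc(-c2nc(Nc3ccc(Br)cc3)c3cc(F)ccc3n2)c1` gives > 50000 nM as its result, again a limit. Compound 3 `Cc1ccc(Nc2nc(-c3cccc(F)c3)nc3ccc(F)cc23)cc1` gives > 50000 nM as its result, also a limit, so compound 3 has no exact place on the scale.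

Compound 4 `Cc1ccccc1Nc1nc(-c2cccc(F)c2)nc2ccc(F)cc12` has not yet been measured. It has the same atoms as compound 3 joined differently, as 2-methylphenyl in place of 4-methylphenyl on a nitrogen on an aromatic ring sets out: 2-methylphenyl in place of 4-methylphenyl on a nitrogen on an aromatic ring.

All three measured steps change the group on that nitrogen. They are a step that the two limits leave unreadable from compound 1 to compound 2 and a step that the two limits leave unreadable from compound 1 to compound 3 and a step that the two limits leave unreadable from compound 2 to compound 3 in turn, and none has a readable size. The whole record is the limit of > 50000 nM in this assay, at which 3 of the 3 values shown sit, and nothing more. Judging by compound 3 and the step that the two limits leave unreadable from compound 1 to compound 3 along with the other two, no change beyond the usual scatter is expected in either direction in this assay for this move. The expected outcome is a number no higher from compound 3 to compound 4 (the limit leaves the size open) on this estimate. For compound 4 the estimate is 50000 nM with an expected range from 20000 nM to 100000 nM overall. Another limit is the likeliest report.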

Compound 4, half-maximal inhibitory concentration: > 50000 nM
Compound 4 ended at the assay's limit; the forecaster's own chance of this, stated with the estimate: 85%; the middle value sits exactly at the limit.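

No step from compound 1, compound 2 or compound 3 to compound 4 can be read, since every result is a limit and not a number: the limit of > 50000 nM in this assay, at which 4 of the 4 values shown sit.

The compounds shown leave open how far each one lies beyond that limit, and so whether 2-methylphenyl in place of 4-methylphenyl changes anything in this assay.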